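A few compounds are considered here, and "the series" means these few. Any claim that something is new, unique, unknown or untested is made for them only; others in the source may bear on it.

Compound 3 `COc1cc(OC)c(C(=O)/C=C/c2ccccc2SC)c(OC)c1` gives 36% in a functional assay on Caco-2 cells (Homo sapiens), read by fluorescence and BrdU incorporation, with a stated time of 48 h, tested at 10 uM; on this read-out lower numbers stand for a stronger effect and higher numbers for a weaker effect at the one concentration tested. Its two neighbours, compound 1 `COc1cc(OC)c(C(=O)/C=C/c2ccc(Cl)cc2)c(OC)c1` with 39% and compound 2 `COc1cc(OC)c(C(=O)/C=C/c2ccc(Br)cc2)c(OC)c1` with 36%, differ from it only in the aryl group on the double-bonded chain, and both steps, a number 3 percentage points lower from compound 1 to compound 3 (within the scatter) and no change at the digits printed from compound 2 to compound 3 (within the scatter), stay within the scatter, so all three sit at one level on this read-out. Compound 4 `COc1cc(O)c(C(=O)/C=C/c2ccccc2SC)c(OC)c1` changes a different place: hydrogen in place of methyl on an oxygen on an aromatic ring on the shared core. For the measured compounds named here, no measured step touches that oxygen, so nothing here speaks to it directly; the steps that do exist, including a number 3 percentage points lower from compound 1 to compound 2 (within the scatter), were all small. Compound 4 is therefore expected to give about 38%, between 22% and 55%. The step of a number 2 percentage points higher from compound 3 to compound 4 (within the scatter) is estimated to stay within the scatter.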

Compound 4, a percentage reported as activity, at one concentration (the size of the read-out at that concentration, not a potency): 50%
Compound 4: middle estimate off by 12 percentage points, on the low side, within the range that was stated.
By their numbers in this assay, from the lowest: compounds 2, 3 and 1 (each within the scatter of the next); then compound 4.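

Methoxy to hydroxy on the shared core gives a number 14 percentage points higher from compound 3 to compound 4 (beyond the scatter) in this assay, which means a weaker effect at the one concentration tested. For the compounds shown here, this is the only step in the set that goes beyond the scatter, as all the steps between aryl groups stayed within it, so this oxygen's methyl group counts for more here than those aryl changes did. No measurement available here accounts for the step.

From the compounds shown here alone, it remains open whether methoxy to hydroxy would act alike with the 4-chlorophenyl or 4-bromophenyl group in place. Going by these compounds, how an ethyl group on that oxygen would read is also open.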